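Notes on the step from compound 3 to compound 4

The source may report more compounds than this note shows. Statements on the series, on what has been measured and on what is new or still open speak of the compounds shown alone.

Measured so far in a functional assay on aorta (Rattus norvegicus, strain Sprague-Dawley) for inhibition (on this read-out lower numbers stand for an effect already at smaller amounts and higher numbers for an effect only at larger amounts of compound), as follows:
- compound 1 `Cc1cc2c(c3c1C[C@@H]1[C@@H](C)CO[C@]1(C)O3)C[C@@H]1[C@@H](C)CO[C@]1(C)O2` at 40000 nM
- compound 2 `C#CCOc1cc2c(c3c1C[C@@H]1[C@@H](C)CO[C@]1(C)O3)C[C@@H]1[C@@H](C)CO[C@]1(C)O2` at 23000 nM
- compound 3 `COc1cc2c(c3c1C[C@@H]1[C@@H](C)CO[C@]1(C)O3)C[C@@H]1[C@@H](C)CO[C@]1(C)O2` at 17000 nM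

Going by the values given here, compound 3 stands clear of compound 1 only: a 2.4-fold lower number from compound 1 to compound 3 (0.37 log units; beyond the scatter) is the one measured step beyond the scatter. Against compound 2 it stands level, with a 1.4-fold lower number from compound 2 to compound 3 (0.13 log units; within the scatter) as the gap. Compound 2 itself shows a 1.7-fold lower number from compound 1 to compound 2 (0.24 log units; within the scatter) as its step from the methyl member.

Compound 4 `C[C@H]1CO[C@]2(C)Oc3cc(OC/C=C/c4ccccc4)c4c(c3C[C@H]12)O[C@@]1(C)OC[C@H](C)[C@H]1C4` awaits measurement in this assay and differs from compound 3 as follows: 2-phenylethenyl in place of hydrogen on a saturated chain carbon bound to an oxygen on an aromatic ring in words, 2-phenylethenyl in place of hydrogen on a saturated chain carbon bound to an oxygen on an aromatic ring. Cut one bond further out, this reads methoxy to (3-phenylprop-2-en-1-yl)oxy.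

The closest evidence is the change at that same carbon, where compound 2 and compound 3 give a 1.4-fold lower number from compound 2 to compound 3 (0.13 log units; within the scatter) as their step. None of the three measured compounds has a group with an aromatic ring at this place, so the new group lies outside the measured range of substituents. All three measured steps are small, and they give no firm direction. Among the compounds with values here, the expected result is a 1.2-fold higher number from compound 3 to compound 4 (0.07 log units; within the scatter) and no step clearly beyond the scatter is anticipated. For compound 4 the estimated value is 20000 nM with 6000 nM to 50000 nM as the expected range.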

Compound 4, half-maximal effective concentration: 64000 nM
Compound 4: the middle estimate sits 3.2-fold (0.51 log units) below what was measured, outside the stated range (above it).
By their numbers in this assay, from the lowest: compounds 3, 2, 1 and 4 (each within the scatter of the next, the first and the last beyond it).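

In this assay, going by these compounds alone, the earlier steps at this carbon stayed within the scatter, whereas 2-phenylethenyl in place of hydrogen on a saturated chain carbon bound to an oxygen on an aromatic ring gives the first change there that lies beyond it (a 3.8-fold higher number from compound 3 to compound 4 (0.58 log units; beyond the scatter)), and 2-phenylethenyl in place of ethynyl at the same carbon also lies beyond it (a 2.8-fold higher number from compound 2 to compound 4 (0.44 log units; beyond the scatter)). The number therefore moves in the unfavourable direction with this larger group, which brings one six-membered aromatic ring and one double bond outside aromatic rings, while the comparison with the methyl member stays within the scatter (a 1.6-fold higher number from compound 1 to compound 4 (0.20 log units; within the scatter)), so the advantage that the methoxy member held over the methyl member is not kept by this larger ether. Nothing measured here explains the loss.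

The compounds shown do not separate the part played by the phenyl ring from that of the double bond or of chain length, which a saturated 3-phenylpropoxy group, a benzyloxy group or a plain propoxy group would address. They also leave open how a free hydroxyl, an amine or a carboxylic acid at this aromatic carbon would read in this assay.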